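Series notes: methoxy removal from compound 1 to compound 4

A few compounds are considered here, and "the series" means these few. Any claim that something is new, unique, unknown or untested is made for them only; others in the source may bear on it.

Measured in a functional assay on MCF7 cells (Homo sapiens) for cytotoxicity, read by sulforhodamine B assay; a higher number here means a weaker inhibitor, a lower number a stronger inhibitor:
- compound 1 `C=C1[C@@H](OC(C)=O)C[C@@H]2[C@](C)(CO[Si](C)(C)C(C)(C)C)[C@H](OC(C)=O)CC[C@@]2(C)[C@@H]1C[C@@H](Nc1ccc(OC)c(OC)c1)C1=CCOC1=O`: 4310 nM
- compound 2 `C=C1CC[C@@H]2[C@](C)(CO[Si](C)(C)C(C)(C)C)[C@H](OC(C)=O)CC[C@@]2(C)[C@@H]1C/C=C1/C(=O)OC[C@H]1OC(C)=O`: 4840 nM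
- compound 3 `C=C1[C@@H](OC(C)=O)C[C@@H]2[C@](C)(COC=O)[C@H](OC(C)=O)CC[C@@]2(C)[C@@H]1C[C@@H](Nc1cccc2ccccc12)C1=CCOC1=O`: 9750 nM

Compound 1 holds the lowest number of the three in this assay. Its nearest neighbour is compound 2, whose number lies within the scatter of it, so no order between the two can be claimed. Compound 3 sits further off, beyond the scatter, and differs from compound 1 in more than one place, so its two values are all that can be said of that pair.

Compound 4 `C=C1[C@@H](OC(C)=O)C[C@@H]2[C@](C)(CO[Si](C)(C)C(C)(C)C)[C@H](OC(C)=O)CC[C@@]2(C)[C@@H]1C[C@@H](Nc1ccc(OC)cc1)C1=CCOC1=O` is not yet measured. Against compound 1 it shows (hydrogen in place of methoxy on an aromatic carbon). Among the measured compounds shown here, no measured pair in this set isolates such a change. The expectation is a step of a 1.3-fold higher number from compound 1 to compound 4 (0.11 log units; within the scatter) of modest size, if any, with the number for compound 4 estimated at 5500 nM and a range of 2500 nM to 12000 nM.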

Compound 4, half-maximal inhibitory concentration: 4280 nM
Beside the measured number, compound 4's estimate is 1.3-fold (0.11 log units) above it; the range from low to high includes it.
By their numbers in this assay, from the lowest: compounds 4, 1, 2 and 3 (each within the scatter of the next, the first and the last beyond it).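

In this assay, among the compounds shown here, hydrogen in place of methoxy on this aromatic carbon gives a 1.0-fold lower number from compound 1 to compound 4 (0.00 log units; within the scatter), the first step in the set that isolates a single change. At this position, (3,4-dimethoxyphenyl)amino and (4-methoxyphenyl)amino therefore cannot be told apart in this assay, and the methoxy group that leaves is not needed to hold the value of compound 1. Nothing available accounts for this result. The compounds shown leave open what a hydroxyl group, a fluorine atom or an ethoxy group would give on this carbon. From the compounds shown here alone, the contribution of the remaining methoxy group also stays open.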